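Swapping an alkyl chain for a dialkylamino group on the core

This account rests on a few compounds, and the source may have more. Where it says the series, first, only, none or still open, it means among the compounds named here.

Measured compounds:
- compound 1, `CCc1nc(-c2ccc(Cl)cc2Cl)c(CC)nc1SC(C)CC`: 0.283 h
- compound 2, `CCCN(CC1CC1)c1nc(CC)c(-c2ccc(Cl)cc2Cl)nc1CC`: 0.2 h
- compound 3, `CCc1nc(-c2ccc(Cl)cc2Cl)c(CC)nc1CC(CC)CC`: 0.217 h

These three compounds share one core and differ only in the group on a single aromatic carbon. In an in vitro ADME assay on microsomes (Homo sapiens) for metabolic stability (on this read-out higher numbers stand for a longer-lived compound and lower numbers for a shorter-lived compound), compound 1 gives 0.283 h, compound 2 gives 0.2 h and compound 3 gives 0.217 h. Compound 3 stands within the usual scatter of both neighbours: the step of a 1.3-fold lower number from compound 1 to compound 3 (0.12 log units; within the scatter) and the step of a 1.1-fold higher number from compound 2 to compound 3 (0.04 log units; within the scatter) are both too small to count as real differences, as is a 1.4-fold lower number from compound 1 to compound 2 (0.15 log units; within the scatter).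

Compound 4, `CCc1nc(N(CC2CC2)CC2CC2)c(CC)nc1-c1ccc(Cl)cc1Cl`, is not yet measured. Compared with compound 3 the change is bis(cyclopropylmethyl)amino in place of 2-ethylbutyl on an aromatic carbon. The step that bears most directly on it is a 1.1-fold higher number from compound 2 to compound 3 (0.04 log units; within the scatter), where a group built on the same amino nitrogen gave essentially the same number as the 2-ethylbutyl chain; the step of a 1.4-fold lower number from compound 1 to compound 2 (0.15 log units; within the scatter) points the same way. No shift beyond the scatter is therefore expected, and the estimated step is a 1.1-fold lower number from compound 3 to compound 4 (0.04 log units; within the scatter). Compound 4 is expected to give about 0.2 h in this assay, within a range of 0.1 h to 0.4 h.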

Compound 4, half-life: 0.133 h
Compound 4: the middle estimate sits 1.5-fold (0.18 log units) above what was measured, and the stated range covers the measured number.
By their numbers in this assay, from the lowest: compounds 4, 2, 3 and 1 (each within the scatter of the next, the first and the last beyond it).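

Among these compounds, with bis(cyclopropylmethyl)amino on this aromatic carbon, this assay shows the only step in this set that lies beyond the usual scatter, a modest one: a 2.1-fold lower number from compound 1 to compound 4 (0.33 log units; beyond the scatter), with (sec-butyl)sulfanyl as the group replaced. The two closer comparisons stay within the scatter, both a 1.6-fold lower number from compound 3 to compound 4 (0.21 log units; within the scatter) for the exchange with 2-ethylbutyl and a 1.5-fold lower number from compound 2 to compound 4 (0.18 log units; within the scatter) for cyclopropyl in place of ethyl on the amino side chain, so neither can be read as a real difference. Among the compounds shown here, no measurement here accounts for the one step that can be read.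

The compounds shown leave open whether the sulfur link or the particular chains on it set compound 1 apart from compound 4. They also leave open how a morpholine ring or a chain ending in a hydroxyl group would read at this position.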